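A few compounds are considered here, and "the series" means these few. Any claim that something is new, unique, unknown or untested is made for them only; others in the source may bear on it.

Within the data shown here, in a functional assay on DU-145 cells (Homo sapiens) for inhibition, read by trypan blue exclusion, with a stated time of 96 h (on this read-out lower numbers stand for stronger inhibition of growth and higher numbers for weaker inhibition of growth), compound 1 (`O=C(O)c1ccc(C(=O)/C(=C\c2ccc(Cl)c([N+](=O)[O-])c2)SCc2ccc(F)cc2)cc1`) gives 1000 nM, the lower of the two numbers measured so far. The other measured compound, compound 2 (`CN(C)c1ccc(/C=C(/SCc2ccc(F)cc2)C(=O)c2ccc(C(=O)O)cc2)cc1`), gives 10000 nM. Compound 3 (`Cc1ccc(CS/C(=C/c2ccc(Cl)c([N+](=O)[O-])c2)C(=O)c2ccc(C(=O)O)cc2)cc1`) keeps the 4-chloro-3-nitrophenyl group of compound 1 and differs from it at one place only: methyl in place of fluoro on an aromatic carbon. This is methyl in place of fluoro on an aromatic carbon, para to a large group, so 4-fluorobenzyl becomes 4-methylbenzyl.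

Among the measured compounds shown here, only one measured step is available: a 10-fold higher number from compound 1 to compound 2 (1.00 log units; beyond the scatter). That step exchanged 4-chloro-3-nitrophenyl for 4-(dimethylamino)phenyl, a part of the structure that compound 3 leaves untouched, so it bears on the new change only indirectly. For the measured compounds named here, no measured pair varies the 4-fluorobenzyl group, and the data give no direction for this exchange. No shift beyond the scatter is therefore expected in this assay, and the expected step is no change at the digits printed from compound 1 to compound 3 (within the scatter). For compound 3 the estimated value is 1000 nM, with an expected range from 350 nM to 3000 nM.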

Compound 3, concentration for 50% growth inhibition: 1000 nM
The estimate for compound 3 equals the measured number at the digits printed; the measured number falls inside the stated range.
By their numbers in this assay, from the lowest: compounds 1 and 3 (each within the scatter of the next); then compound 2.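

In this assay, replacing the 4-fluorobenzyl group with 4-methylbenzyl gives no change at the digits printed from compound 1 to compound 3 (within the scatter) and so leaves the growth-inhibition read-out unmoved. Among these compounds, the one earlier step, a 10-fold higher number from compound 1 to compound 2 (1.00 log units; beyond the scatter), lay at the 4-chloro-3-nitrophenyl group, so this result is the first view of the other end of the molecule, where an aromatic carbon, para to a large group, accepts methyl in place of fluoro with no shift beyond the scatter, though this rests on a single pair of compounds. Nothing given here explains why the two compounds read alike.

The compounds shown leave open whether this position stays as undemanding with a group other than fluoro or methyl, such as a methoxy group, an amine or a carboxylic acid, or whether a longer chain in place of the benzyl linkage would move the number. Among the compounds shown here, they also leave open whether the same exchange would read alike on the 4-(dimethylamino)phenyl background of compound 2, since the one flat step comes from the 4-chloro-3-nitrophenyl series alone.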